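The compounds below may be only part of what the source reports. "The series", "measured", "known", "first", "only" and "open" are said of these compounds alone.

Working notes on the series built on the core of compound 1 `O=[N+]([O-])c1c(CS(=O)(=O)c2ccccc2)nc2c(-c3ccccc3CO)cc(Cl)cn12`. Within the data shown here, in an ADME assay on HepG2 cells (Homo sapiens) for cytotoxicity, read by MTT assay, with a stated time of 72 h (a higher number here means that more compound is tolerated, a lower number that less compound is tolerated), compound 1 gives 88000 nM, the only actual number so far. Compound 2 `O=[N+]([O-])c1c(CS(=O)(=O)c2ccccc2)nc2c(-c3cccc(F)c3)cc(Cl)cn12` is reported only as a limit, > 12500 nM. Compound 3 `O=[N+]([O-])c1c(CS(=O)(=O)c2ccccc2)nc2c(-c3ccccc3F)cc(Cl)cn12` is likewise reported only as a limit, > 3900 nM, so it has no number of its own to start from.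

The next compound is compound 4 `O=[N+]([O-])c1c(CS(=O)(=O)c2ccccc2)nc2c(-c3ccc(F)cc3F)cc(Cl)cn12`, and its difference from compound 3 is this: fluoro in place of hydrogen on an aromatic carbon. In words, this is fluoro in place of hydrogen on an aromatic carbon, taking 2-fluorophenyl to 2,4-difluorophenyl.

Among the measured compounds shown here, none of the measured steps supplies a size. They are a step that the two limits leave unreadable from compound 2 to compound 3, a step that the limit leaves unreadable from compound 1 to compound 2 and a step that the limit leaves unreadable from compound 1 to compound 3. The first is the closest in kind, since it also concerns fluoro on the phenyl group, but it gives no magnitude. For the measured compounds named here, the one number available is that of compound 1 at 88000 nM, so the expectation for compound 4 in this assay is a high value rather than a low one. The result for compound 4 may possibly be reported again as a limit. The expected change is a step that the limit leaves unreadable from compound 3 to compound 4, upward in number, though it is reckoned from a limit and not from a measured value. For compound 4 the estimate is 20000 nM, with an expected range from 5000 nM to 90000 nM.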

Compound 4, half-maximal cytotoxic concentration: > 7800 nM
Compound 4: no number, only a limit; the forecaster's own chance of this, stated with the estimate: 65%; the middle value does not contradict the limit.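

In this assay, among these compounds, compound 4 is reported only as a limit, > 7800 nM, so no step to it from compound 1, compound 2 or compound 3 can be read. The compounds shown leave open how large the step for fluoro in place of hydrogen on an aromatic carbon is, and how compound 2, compound 3 and compound 4 stand against compound 1.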